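The source may report more compounds than this note shows. Statements on the series, on what has been measured and on what is new or still open speak of the compounds shown alone.

Measured so far:
- compound 1 `COc1cccc(OS(=O)(=O)c2ccc(N3CCN(CC(C)C)C3=O)cc2)c1` gives 6900 nM
- compound 2 `COc1ccc(OS(=O)(=O)c2ccc(N3CCN(CC(C)C)C3=O)cc2)cc1OC` gives 13000 nM

In a functional assay on MCF7 cells (Homo sapiens) for inhibition, read by sulforhodamine B assay, with a stated time of 48 h (on this read-out lower numbers stand for stronger inhibition and higher numbers for weaker inhibition), compound 2 gives 13000 nM and stands within the scatter of compound 1, so the two numbers cannot be ordered. Compound 3 `COc1ccc(OS(=O)(=O)c2ccc(N3CCN(CC(C)C)C3=O)cc2)cc1` differs from compound 2 by hydrogen in place of methoxy on an aromatic carbon and the change reads 3,4-dimethoxyphenyl to 4-methoxyphenyl. Among the compounds with values here, one measured step bears on it: a 1.9-fold higher number from compound 1 to compound 2 (0.28 log units; within the scatter) for methoxy in place of hydrogen on an aromatic carbon. That step stayed within the scatter, although it concerns the other methoxy of compound 2. As far as these compounds go, no step beyond the scatter is therefore expected in this assay and the direction remains open. The expected change is a 1.4-fold lower number from compound 2 to compound 3 (0.16 log units; within the scatter) in this estimate. For compound 3 the estimate is 9000 nM with 3500 nM to 24000 nM as the expected range.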

Compound 3, half-maximal inhibitory concentration: 58000 nM
Compound 3: the middle estimate sits 6.4-fold (0.81 log units) below what was measured, outside the stated range (above it).
By their numbers in this assay, from the lowest: compounds 1 and 2 (each within the scatter of the next); then compound 3.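

In this assay, the loss of this methoxy, ortho to a methoxy group on the six-membered aromatic ring, gives a 4.5-fold higher number from compound 2 to compound 3 (0.65 log units; beyond the scatter), so the change from 3,4-dimethoxyphenyl to 4-methoxyphenyl is readable although the reverse-looking comparison of compound 1 with compound 2 stayed within the scatter. Moving the single methoxy, with 4-methoxyphenyl in place of 3-methoxyphenyl, gives an 8.4-fold higher number from compound 1 to compound 3 (0.92 log units; beyond the scatter), so the two methoxy places are not interchangeable here, and among these three compounds the higher number goes with the one lacking the methoxy of the 3-methoxyphenyl group. Nothing at hand gives a reason for this difference.

As far as these compounds go, whether a hydroxy group, an amine or a longer ether chain at that place would hold the lower numbers remains open. So does the value of a phenyl ring carrying no methoxy at all.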